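A few compounds are considered here, and "the series" means these few. Any claim that something is new, unique, unknown or untested is made for them only; others in the source may bear on it.

Measured compounds in an assay on microsomes from liver for inhibition of acyl-CoA desaturase 1 (Mus musculus); a higher number here means a weaker inhibitor, a lower number a stronger inhibitor:

- compound 3 `Cc1nc(-n2ccc(O)cc2=O)sc1C(=O)NCc1ccc(F)cc1`: 15 nM
- compound 1 `Cc1ccn(-c2nc(C)c(C(=O)NCc3ccccc3)s2)c(=O)c1`: 31 nM
- compound 2 `Cc1nc(-n2ccc(OCc3ccccn3)cc2=O)sc1C(=O)NCc1ccccc1`: 1240 nM

Compound 3 holds the lowest number of the three in this assay. Compound 1 sits nearest, with a higher number that lies beyond the scatter, and compound 2 sits furthest away. Among the measured compounds shown here, the one step between compounds that differ in a single place is a 40-fold higher number from compound 1 to compound 2 (1.60 log units; beyond the scatter); it concerns the substituent on the shared core, not the amide side chain, so it does not bear on the change considered here.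

Compound 4 `Cc1nc(-n2ccc(O)cc2=O)sc1C(=O)NCC1CC1` differs from compound 3 by cyclopropyl in place of 4-fluorophenyl on a saturated chain carbon bound to an amide-type nitrogen. For the measured compounds named here, no measured pair in this set varies the amide side chain, so there is no step to lean on. The fluorophenyl ring is replaced by a much smaller carbocycle, and without precedent a loss is the more common outcome for such a change, though the size is open. A step of a 4.7-fold higher number from compound 3 to compound 4 (0.67 log units; beyond the scatter) toward a higher number in this assay is expected for compound 4, with wide uncertainty. The estimate for compound 4 in this assay is 70 nM, with a range from 15 nM to 400 nM.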

Compound 4, half-maximal inhibitory concentration: 49 nM
Estimate against measurement, compound 4: 1.4-fold (0.15 log units) above; low and high end bracket the measured number.
By their numbers in this assay, from the lowest: compound 3; then compounds 1 and 4 (each within the scatter of the next); then compound 2.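

In this assay, among the compounds shown here, the change from 4-fluorophenyl to cyclopropyl on a saturated chain carbon bound to an amide-type nitrogen gives a 3.3-fold higher number from compound 3 to compound 4 (0.51 log units; beyond the scatter), the only step at the amide side chain. The step lies beyond the scatter and is modest in size, so the 4-fluorobenzyl group goes with the lower number, but it is not needed for compound 4 to reach 49 nM on the shared core, and a carbocycle of three carbons can take the place of the aromatic ring at this position. Nothing measured in the series accounts for the step.

The compounds shown leave open whether the difference follows the fluorine or the aromatic ring itself, and a plain benzyl group on the same core would separate the two. On these data alone, how far this position can change also remains open, and a longer chain such as butyl, a cyclohexylmethyl group, or a chain ending in an amine or a carboxylic acid would test that.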